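Ring-nitrogen substituent series: a carboxyphenylsulfonyl analogue

This account rests on a few compounds, and the source may have more. Where it says the series, first, only, none or still open, it means among the compounds named here.

Compound 2 `O=C(c1ccccn1)N1CCC(NS(=O)(=O)c2cc(S(=O)(=O)c3ccccc3)ccc2C(F)(F)F)CC1` gives 230 nM in an assay on U2OS cells for inhibition of secreted frizzled-related protein 1 (Homo sapiens), read by a luciferase reporter, with a stated time of 18 h; a higher number here means that more compound is needed for the effect, a lower number that less compound is needed. Compound 1 `CN(C)c1ccc(C(=O)N2CCC(NS(=O)(=O)c3cc(S(=O)(=O)c4ccccc4)ccc3C(F)(F)F)CC2)cc1` gives 190 nM and compound 3 `O=S(=O)(NC1CCN(S(=O)(=O)c2ccccc2)CC1)c1cc(S(=O)(=O)c2ccccc2)ccc1C(F)(F)F` gives 210 nM. The steps of a 1.2-fold higher number from compound 1 to compound 2 (0.08 log units; within the scatter) and a 1.1-fold lower number from compound 2 to compound 3 (0.04 log units; within the scatter) both lie within the scatter, as does a 1.1-fold higher number from compound 1 to compound 3 (0.04 log units; within the scatter), so compound 2 is not separated from either of the others. Compound 4 `O=C(O)c1cccc(S(=O)(=O)N2CCC(NS(=O)(=O)c3cc(S(=O)(=O)c4ccccc4)ccc3C(F)(F)F)CC2)c1` differs from compound 2 by (3-carboxyphenyl)sulfonyl in place of (pyridin-2-yl)carbonyl on an amine nitrogen in a ring. Among the measured compounds shown here, the step from compound 2 to compound 3 bears most directly, since it exchanges the same carbonyl group for a phenylsulfonyl with no effect beyond the scatter; the carboxy group itself has no counterpart among the measured compounds. A step of a 1.1-fold higher number from compound 2 to compound 4 (0.04 log units; within the scatter) is therefore expected for compound 4, essentially none beyond the scatter, with widened uncertainty. Compound 4 is estimated at 250 nM, range 100 nM to 700 nM.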

Compound 4, half-maximal effective concentration: 190 nM
The estimate for compound 4 lay 1.3-fold (0.12 log units) above the measured number; measured number inside the range.
By their numbers in this assay, from the lowest: compounds 1, 4, 3 and 2 (each within the scatter of the next).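

Carboxy in place of hydrogen on an aromatic carbon of the phenylsulfonyl group adds no step beyond the scatter in this assay, with a 1.1-fold lower number from compound 3 to compound 4 (0.04 log units; within the scatter). The (3-carboxyphenyl)sulfonyl group also stays within the scatter of both carbonyl-linked groups on the amine nitrogen, with a 1.2-fold lower number from compound 2 to compound 4 (0.08 log units; within the scatter) and no change at the digits printed from compound 1 to compound 4 (within the scatter). No supporting data are available to explain this tolerance. The compounds shown leave open whether an amine in place of the carboxy group, or a longer chain carrying the carboxylic acid, would give a step beyond the scatter.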